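Anilino in place of benzyl on the shared core

This account rests on a few compounds, and the source may have more. Where it says the series, first, only, none or still open, it means among the compounds named here.

Working notes on a small set sharing one core. Compound 1 `Cc1ccccc1Nc1nc(Nc2ccccn2)ncc1Cl` gives 11200 nM in a functional assay on MDA-MB-231 cells (Homo sapiens) for inhibition, read by CCK-8 assay, with a stated time of 48 h; a lower number here means a stronger inhibitor of growth, a higher number a weaker inhibitor of growth. Compound 2 `CCN1CCN(c2ccc(Nc3ncc(Cl)c(Nc4ccccc4C)n3)cc2)CC1` gives 3040 nM in this assay. For compound 3 `CN1CCN(c2ccc(Nc3ncc(Cl)c(NCc4ccc(F)cc4)n3)nc2)CC1` the read-out > 100000 nM is a limit of this assay, not a number, so compound 3 stands at the weak end of what has been measured, with its true value unknown beyond that bound; the line the limit of > 100000 nM in this assay, at which 1 of the 3 values shown sits, records where this limit sits among the values shown.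

Compound 4 `CN1CCN(c2ccc(Nc3ncc(Cl)c(Nc4ccc(C(C)(C)C)cc4)n3)nc2)CC1` has not yet been measured. It differs from compound 3 in one place (4-(tert-butyl)phenyl in place of 4-fluorobenzyl on a nitrogen on an aromatic ring), so the aromatic amine on compound 4 carries a ring directly, as do compounds 1 and 2, both of which return numbers rather than limits.

Among the compounds with values here, no step between two measured compounds is available here, so the size of the change from compound 3 to compound 4 can only be expected, not read off. Since compound 1 shows 11200 nM and compound 2 shows 3040 nM, compound 4 is expected to come in as a number in this assay, a step of an at least 12-fold lower number from compound 3 to compound 4 (1.09 log units; beyond the scatter) in the direction of stronger growth inhibition. Compound 4 is thus estimated at 8000 nM, within 1500 nM to 50000 nM.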

Compound 4, concentration for 50% growth inhibition: 16200 nM
Compound 4: the middle estimate sits 2.0-fold (0.31 log units) below what was measured; the measured number falls inside the stated range.
By their numbers in this assay, from the lowest: compound 2; then compounds 1 and 4 (each within the scatter of the next). At a limit, above all of these: compound 3.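

Within the data shown here, on the shared core, 4-(tert-butyl)phenyl in place of 4-fluorobenzyl on a nitrogen on an aromatic ring gives, in this assay, an at least 6.1-fold lower number from compound 3 to compound 4 (0.79 log units; beyond the scatter), the first reading for a change in one place at this position. As far as these compounds go, with this group in place, compound 4 gives 16200 nM as a number, which shows that this nitrogen tolerates a substituent change that moves the read-out in the direction of stronger growth inhibition, though the true size of the step stays unknown. The other end of the step is not a number, as compound 3 stands at a limit of the assay: the limit of > 100000 nM in this assay, at which 1 of the 4 values shown sits.

The step changes two things at once, the ring set directly on the nitrogen and tert-butyl in place of fluorine on that ring, so the compounds shown do not tell which of the two carries it. From the compounds shown here alone, whether 4-fluorophenyl or 4-(tert-butyl)benzyl on the same nitrogen would read closer to compound 3 or to compound 4 stays open, as does the effect of an amine or a carboxylic acid in place of the tert-butyl.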